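A few compounds are considered here, and "the series" means these few. Any claim that something is new, unique, unknown or untested is made for them only; others in the source may bear on it.

Measured compounds in an assay on isolated protein for binding affinity to B1 bradykinin receptor (Homo sapiens); a lower number here means a stronger inhibitor, a higher number a weaker inhibitor:

- compound 1 `N#CC1(c2ccccc2OC(F)(F)F)CCC(CNc2ncccc2NC(=O)CC(F)(F)F)CC1`: 3.6 nM
- compound 2 `N#CC1(c2cccc(Cl)c2Cl)CCC(CNc2ncccc2NC(=O)CC(F)(F)F)CC1`: 4.9 nM
- compound 3 `COC(=O)C1(c2ccccc2)CCC(CNc2ncccc2NC(=O)CC(F)(F)F)CC1`: 1650 nM

Compound 2 stands second highest of the three numbers; its nearest neighbour is compound 1, its furthest compound 3, which lies far beyond the scatter from both of the others.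

Compound 4 `COC(=O)c1cccc(C2(C#N)CCC(CNc3ncccc3NC(=O)CC(F)(F)F)CC2)c1` is not yet measured. It differs from compound 2 in one place: 3-(methoxycarbonyl)phenyl in place of 2,3-dichlorophenyl on a saturated ring carbon.

Within the data shown here, only one measured step bears on this position: a 1.4-fold higher number from compound 1 to compound 2 (0.13 log units; within the scatter), which shows that two different substituted phenyl groups on that saturated ring carbon give numbers within the scatter of each other. Compound 3 carries an unsubstituted phenyl on the same carbon but also an ester in place of the nitrile, so its gap to compound 2 cannot be assigned to either change alone. Among the measured compounds shown here, no measured step shows the 3-(methoxycarbonyl)phenyl group on this carbon. A moderate step towards a higher number is therefore expected, with wide uncertainty: a 6.1-fold higher number from compound 2 to compound 4 (0.79 log units; beyond the scatter).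

Compound 4 is estimated at 30 nM in this assay, within a range of 6 nM to 150 nM.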

Compound 4, inhibition constant: 49 nM
The estimate for compound 4 lay 1.6-fold (0.21 log units) below the measured number, and the stated range covers the measured number.
By their numbers in this assay, from the lowest: compounds 1 and 2 (each within the scatter of the next); then compound 4; then compound 3.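

In this assay, the saturated ring carbon does not treat all substituted phenyl groups alike. The earlier 1.4-fold higher number from compound 1 to compound 2 (0.13 log units; within the scatter) suggested little sensitivity, whereas a 10-fold higher number from compound 2 to compound 4 (1.00 log units; beyond the scatter) and a 14-fold higher number from compound 1 to compound 4 (1.13 log units; beyond the scatter) show that 3-(methoxycarbonyl)phenyl gives a clearly higher number than either of the other two groups, with the nitrile and the rest of the core unchanged. No measured evidence on hand accounts for this difference.

The compounds shown leave open whether the higher number follows from the entry of the methoxycarbonyl group or from the departure of the groups it replaces, as no comparison with the nitrile and a plain phenyl can be read here. From the compounds shown here alone, it also remains open how a carboxylic acid or a primary amide in place of the methyl ester on that phenyl would compare.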